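The compounds below may be only part of what the source reports. "The series", "measured", "known", "first", "only" and "open" are said of these compounds alone.

Of the compounds shown here, three sharing one core have so far been measured in a functional assay on the whole organism (strain Wistar) for inhibition, with Rattus norvegicus as the target, read by paw edema, with stated times of 60 min and 3 h, at a dose of 100 mg/kg by the oral route; on this read-out higher numbers stand for more inhibition at the one dose given (going by the name of the read-out) and lower numbers for less inhibition. Compound 1 `COc1cc2c(cc1OC)C(CC(=O)O)CC2` gives 27.5%. Compound 2 `CCNC(=O)CC1CCc2cc(OC)c(OC)cc21` gives 26.1%, and compound 3 `CCCCCNC(=O)CC1CCc2cc(OC)c(OC)cc21` gives 37.7%. Compound 3 stands highest of the three: the step of a number 10.2 percentage points higher from compound 1 to compound 3 (beyond the scatter) is beyond the scatter, as is the step of a number 11.6 percentage points higher from compound 2 to compound 3 (beyond the scatter), while the step of a number 1.4 percentage points lower from compound 1 to compound 2 (within the scatter) lies within the scatter.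

Compound 4 `COc1cc2c(cc1OC)C(CC(=O)NCc1ccccc1)CC2` has not yet been measured. Relative to compound 3 the change is phenyl in place of butyl on a saturated chain carbon bound to an amide-type nitrogen. The measured steps that bear on this are the two that alter the group attached to the amide-type nitrogen, namely a number 11.6 percentage points higher from compound 2 to compound 3 (beyond the scatter) and a number 10.2 percentage points higher from compound 1 to compound 3 (beyond the scatter), both modest gains. Neither of these, however, puts an aromatic ring in place of a chain, so nothing measured here tells the direction for compound 4 with confidence. The expectation is a step of a number 2.7 percentage points lower from compound 3 to compound 4 (within the scatter), which is not clearly beyond the scatter in either direction. Compound 4 is therefore expected to give about 35% in this assay, within a range from 22% to 48%.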

Compound 4, a percentage reported as inhibition, in the whole organism at one dose (the size of the read-out at that dose, not a potency): 14.5%
Compound 4: middle estimate off by 20.5 percentage points, on the high side; the whole stated range lies above it.
By their numbers in this assay, from the lowest: compound 4; then compounds 2 and 1 (each within the scatter of the next); then compound 3.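

Placing an aromatic ring on a saturated chain carbon bound to an amide-type nitrogen does not behave like extending the chain: in this assay, the change from pentylamino to benzylamino gives a number 23.2 percentage points lower from compound 3 to compound 4 (beyond the scatter). The benzylamino compound also falls short of both the ethylamino compound, with a number 11.6 percentage points lower from compound 2 to compound 4 (beyond the scatter), and the parent carboxylic acid, with a number 13 percentage points lower from compound 1 to compound 4 (beyond the scatter), so the group on this nitrogen can lower the number as well as raise it, and compound 4 goes against the rise seen from ethylamino to pentylamino. No available evidence explains the fall.

The compounds shown do not separate the effect of the aromatic ring from that of its place on the chain: a phenethylamino group would set the phenyl one carbon further from the nitrogen, while a cyclohexylmethylamino group would replace the phenyl with a saturated ring. They also leave open what a hexylamino or longer chain would do, and whether a methoxy group or a chlorine atom on the phenyl ring would change the result for compound 4.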